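The compounds below may be only part of what the source reports. "The series", "measured", "known", "first", "only" and "open" are said of these compounds alone.

Measured so far:
Compound 1, `O=S(=O)(CC1=NCCO1)C1C(c2ccc(Cl)cc2)=NOC1c1ccc(Cl)cc1`, in a functional assay, tested at 75 ug/mL (a higher number here means a stronger effect of the compound at the concentration tested, a lower number a weaker effect), compound 1 is reported as "not active" (no number reported).
Compound 2, `COc1ccc(C2=NN(c3ccccc3)C(c3ccc(C)cc3)C2S(=O)(=O)CC2=NCCO2)cc1`, in this assay compound 2 gives 64.3%.
Compound 3, `COc1ccc(C2=NN(c3ccccc3)C(c3ccc(C)cc3)C2S(=O)(=O)CC2=NCCS2)cc1`, in this assay compound 3 gives 43.9%.

Compound 2 and compound 3 share a core and differ only by a group of 5 heavy atoms (3 carbon, 1 nitrogen, 1 sulfur; one five-membered non-aromatic ring with 2 hetero atoms) in place of a group of 5 heavy atoms (3 carbon, 1 nitrogen, 1 oxygen; one five-membered non-aromatic ring with 2 hetero atoms), on a saturated chain carbon bound to a sulfonyl sulfur. That change made a number 20.4 percentage points lower from compound 2 to compound 3 (beyond the scatter). The cores of compound 1 and compound 2 differ, but that difference is not broken down here. Going by the values given here, compound 4, `O=S(=O)(CC1=NCCS1)C1C(c2ccc(Cl)cc2)=NOC1c1ccc(Cl)cc1`, is not yet measured; it differs from compound 1 by a group of 5 heavy atoms (3 carbon, 1 nitrogen, 1 sulfur; one five-membered non-aromatic ring with 2 hetero atoms) in place of a group of 5 heavy atoms (3 carbon, 1 nitrogen, 1 oxygen; one five-membered non-aromatic ring with 2 hetero atoms), on a saturated chain carbon bound to a sulfonyl sulfur, the same change at the same place as the one from compound 2 to compound 3. Since compound 1 is reported as "not active" (no number reported) and the same change lowered the read-out from compound 2 to compound 3, compound 4 is expected to show little or no effect in this assay. The estimate for compound 4 is 5%, between 0% and 25%.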

Compound 4, a percentage reported as activity, at one concentration (the size of the read-out at that concentration, not a potency): "not active" (no number reported)
No number was reported for compound 4, so the estimate cannot be set against anything.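

Compound 1 and compound 4 both come without a reported number, so no step can be read between them, and nothing given here explains their result. On these data alone, whether the ring exchange that separates compound 2 from compound 3 has any effect on the core of compound 1 stays open.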